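This account rests on a few compounds, and the source may have more. Where it says the series, first, only, none or still open, it means among the compounds named here.

Measured so far in a functional assay on cells (Cancer cell lines, Homo sapiens) for cytotoxicity, read by sulforhodamine B assay, with a stated time of 48 h; on this read-out higher numbers stand for weaker inhibition of growth and lower numbers for stronger inhibition of growth:
compound 1 `Oc1ccc(O)c(-c2cc(-c3ccc(Cl)cc3)nn2-c2ccccc2)c1` gives 17900 nM;
compound 2 `CC(=O)NS(=O)(=O)c1ccc(-n2nc(-c3ccccc3)cc2-c2cc(O)ccc2O)cc1` gives 90400 nM;
compound 3 `O=C1C=CC(=O)C(c2cc(-c3ccc(Cl)cc3)nn2-c2ccccc2)=C1` gives 65400 nM.

The difference between the cores of compound 1 and compound 2 is not broken down here; their values show that compound 2 sits at the higher number. Compound 4 `CC(=O)NS(=O)(=O)c1ccc(-n2nc(-c3ccccc3)cc2C2=CC(=O)C=CC2=O)cc1` is not yet measured.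

One change recurs. From compound 1 to compound 3 it is a group of 8 heavy atoms (6 carbon, 2 oxygen; one six-membered non-aromatic ring of carbon only) in place of a group of 8 heavy atoms (6 carbon, 2 oxygen; one six-membered aromatic ring of carbon only), on an aromatic carbon, and it gave a 3.7-fold higher number from compound 1 to compound 3 (0.56 log units; beyond the scatter). From compound 2 to compound 4 it is a group of 8 heavy atoms (6 carbon, 2 oxygen; one six-membered non-aromatic ring of carbon only) in place of a group of 8 heavy atoms (6 carbon, 2 oxygen; one six-membered aromatic ring of carbon only), on an aromatic carbon, the same kind of change, though the surroundings are not identical: in the first pair the site is next to the ring atom that bears a phenyl group and two ring bonds from the ring atom that bears a 4-chlorophenyl group, in the second next to the ring atom that bears a large group and two ring bonds from the ring atom that bears a phenyl group.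

For compound 4 in this assay a step of a 3.1-fold higher number from compound 2 to compound 4 (0.49 log units; beyond the scatter) is expected, resting on the earlier step of a 3.7-fold higher number from compound 1 to compound 3 (0.56 log units; beyond the scatter) and on the value of compound 2, 90400 nM. Compound 4 is therefore estimated at 280000 nM, with a range from 90000 nM to 800000 nM.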

Compound 4, concentration for 50% growth inhibition: 100000 nM
Compound 4: the middle estimate sits 2.8-fold (0.45 log units) above what was measured, and the stated range covers the measured number.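

In this assay putting the non-aromatic ring in place of the 2,5-dihydroxyphenyl group gave a 1.1-fold higher number from compound 2 to compound 4 (0.04 log units; within the scatter) on this core, so here the change leaves no readable difference. The size of the step did not carry over between the two cores: the same change on two cores in this assay, a 3.7-fold higher number (0.56 log units; beyond the scatter) from compound 1 to compound 3 and a 1.1-fold higher number (0.04 log units; within the scatter) from compound 2 to compound 4, 3.3-fold (0.52 log units) apart, beyond the scatter of two such steps

The direction and size seen on one core are therefore a poor guide to the other in this series, but two pairs do not show which feature of the cores governs the step.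

The cores of compound 1 and compound 2 differ in more than one place, and those differences are not separated here. Also open, going by these compounds, is how the same change behaves on a core carrying an amine or a carboxylic acid in place of the large group.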